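Adding Fluorine Beside Bromine on the Anilide Ring

A few compounds are considered here, and "the series" means these few. Any claim that something is new, unique, unknown or untested is made for them only; others in the source may bear on it.

Compound 3 `COc1cc2ncnc(Nc3ccc(Br)cc3)c2cc1OCCCCC(=O)Nc1ccc(S(N)(=O)=O)cc1` reaches only a limit of the assay in a functional assay on A549 cells (Homo sapiens) for antiproliferative activity, read by MTT assay, with a stated time of 72 h (on this read-out lower numbers stand for stronger inhibition and higher numbers for weaker inhibition), where compound 3 gives > 40000 nM. Its two neighbours carry numbers: compound 1 `COc1cc2ncnc(Nc3ccc(F)c(Cl)c3)c2cc1OCCCCC(=O)Nc1ccc(S(N)(=O)=O)cc1` gives 15500 nM and compound 2 `COc1cc2ncnc(Nc3ccc(Cl)c(C(F)(F)F)c3)c2cc1OCCCCC(=O)Nc1ccc(S(N)(=O)=O)cc1` gives 9270 nM in this assay. The step of an at least 2.5-fold higher number from compound 1 to compound 3 (0.41 log units; beyond the scatter) and the step of an at least 4.3-fold higher number from compound 2 to compound 3 (0.63 log units; beyond the scatter) both run toward the limit, (the limit of > 40000 nM in this assay, at which 1 of the 3 values shown sits). Compound 4 `COc1cc2ncnc(Nc3ccc(F)c(Br)c3)c2cc1OCCCCC(=O)Nc1ccc(S(N)(=O)=O)cc1` differs from compound 3 by 3-bromo-4-fluorophenyl in place of 4-bromophenyl on a nitrogen on an aromatic ring. This change mirrors, with bromine in place of chlorine, the pattern of compound 1, which gives 15500 nM. On that ground a measurable number is expected for compound 4, and the step of an at least 2.2-fold lower number from compound 3 to compound 4 (0.34 log units; beyond the scatter) is estimated to point downward. Compound 4 is therefore estimated at 18000 nM, with a range from 8000 nM to 45000 nM.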

Compound 4, half-maximal inhibitory concentration: 16000 nM
The estimate for compound 4 lay 1.1-fold (0.05 log units) above the measured number; the measured number falls inside the stated range.
By their numbers in this assay, from the lowest: compounds 2, 1 and 4 (each within the scatter of the next). At a limit, above all of these: compound 3.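

In this assay, 3-bromo-4-fluorophenyl in place of 4-bromophenyl gives an at least 2.5-fold lower number from compound 3 to compound 4 (0.39 log units; beyond the scatter), so this change on the nitrogen brings a measurable number back to the series. Bromo in place of chloro on an aromatic carbon gives a 1.0-fold higher number from compound 1 to compound 4 (0.01 log units; within the scatter), and the exchange with 4-chloro-3-(trifluoromethyl)phenyl gives a 1.7-fold higher number from compound 2 to compound 4 (0.24 log units; within the scatter), so neither change separates these compounds. Compound 3 remains a limit and not a number: the limit of > 40000 nM in this assay, at which 1 of the 4 values shown sits.

The compounds shown leave open whether 3-bromophenyl or 4-fluorophenyl alone would give a number at this position. From the compounds shown here alone, how an amine or a nitrile on this ring would read also remains open.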